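This account rests on a few compounds, and the source may have more. Where it says the series, first, only, none or still open, it means among the compounds named here.

Among the measured compounds shown here, in a functional assay on the whole organism (artery, strain albino) with Rattus norvegicus as the target, with a stated time of 300 min, at a dose of 10 mg/kg by the oral route (a higher number here means more inhibition at the dose given (going by the name of the read-out), a lower number less inhibition), compound 1 `COc1ccc(C2N=C(SCc3ccccc3)NC(C)=C2C(=O)Nc2ccc(Br)cc2)cc1` gives 16.4%, while compound 2 `COc1ccc(C2N=C(SCc3cccc(Cl)c3)NC(C)=C2C(=O)Nc2ccc(Br)cc2)cc1` gives 39%, the higher of the two numbers measured so far. For the measured compounds named here, the single measured step, a number 22.6 percentage points higher from compound 1 to compound 2 (beyond the scatter), is the only comparison at hand. Compound 3 `COc1ccc(C2N=C(SCc3ccc(Cl)cc3)NC(C)=C2C(=O)Nc2ccc(Br)cc2)cc1` differs from compound 2 by 4-chlorophenyl in place of 3-chlorophenyl on a saturated chain carbon bound to a sulfur. Going by the values given here, no measured step shifts a chloro group within a chlorobenzyl in this way, so no change beyond the scatter is expected, and the estimated step is a number 3 percentage points lower from compound 2 to compound 3 (within the scatter). Compound 3 is therefore expected to give about 36%, within a range from 15% to 60%.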

Compound 3, a percentage reported as inhibition, in the whole organism at one dose (the size of the read-out at that dose, not a potency): 37.9%
Estimate against measurement, compound 3: 1.9 percentage points below, within the range that was stated.
By their numbers in this assay, from the lowest: compound 1; then compounds 3 and 2 (each within the scatter of the next).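

In this assay, moving the chlorine from 3-chlorobenzyl to 4-chlorobenzyl gives a number 1.1 percentage points lower from compound 2 to compound 3 (within the scatter) and so separates neither placement from the other. Chloro in place of hydrogen also gives a number 21.5 percentage points higher from compound 1 to compound 3 (beyond the scatter) at this new place, so the rise seen with 3-chlorobenzyl is not confined to that one arrangement. Nothing available explains this rise. Still open, from the compounds shown here alone, is whether the rise belongs to chloro itself or would also appear with a fluoro, a nitrile or an amine on that aromatic ring. Going by these compounds, a longer chain between the sulfur and the ring also remains open.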